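Aryl variation on the shared core: bromo to phenyl

The source may report more compounds than this note shows. Statements on the series, on what has been measured and on what is new or still open speak of the compounds shown alone.

Measured compounds:
Compound 1, `COc1ccccc1-c1cc2c(n1-c1ccc(O)c(C(=O)O)c1)CCCC2`, in a functional assay on the whole organism (strain Wistar) for inhibition, with Rattus norvegicus as the target, read by paw edema, with stated times of 30 min and 3 h, at a dose of 200 mg/kg by the oral route (a lower number here means less inhibition, a higher number more inhibition at the dose given (going by the name of the read-out)), gives 50%.
Compound 2, `O=C(O)c1cc(-n2c(-c3ccc(Br)cc3)cc3c2CCCC3)ccc1O`, gives 40% in this assay.
Compound 3, `O=C(O)c1cc(-n2c(-c3cccs3)cc3c2CCCC3)ccc1O`, gives 30% in this assay.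

Compound 2 stands second highest of the three numbers. Its neighbours lie within the scatter on both sides: a number 10 percentage points lower from compound 1 to compound 2 (within the scatter), and a number 10 percentage points lower from compound 2 to compound 3 (within the scatter). Within the data shown here, the only step beyond the scatter is a number 20 percentage points lower from compound 1 to compound 3 (beyond the scatter).

Compound 4, `O=C(O)c1cc(-n2c(-c3ccc(-c4ccccc4)cc3)cc3c2CCCC3)ccc1O`, differs from compound 2 in one place: phenyl in place of bromo on an aromatic carbon. All three measured steps swap the aryl group on the same aromatic carbon, so all bear on this change, yet none of them puts a phenyl in place of a bromo. Two of them stay within the scatter and the third is only modest. The expectation for this assay is therefore a step no larger than the scatter, in no settled direction: no change at the digits printed from compound 2 to compound 4 (within the scatter) is what is estimated. For compound 4 the estimate is 40%, with a range from 25% to 55%.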

Compound 4, a percentage reported as inhibition, in the whole organism at one dose (the size of the read-out at that dose, not a potency): 50%
Compound 4: the middle estimate sits 10 percentage points below what was measured; low and high end bracket the measured number.
By their numbers in this assay, from the lowest: compounds 3, 2, 1 and 4 (each within the scatter of the next, the first and the last beyond it).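

In this assay, phenyl in place of bromo gives a number 10 percentage points higher from compound 2 to compound 4 (within the scatter), so this aromatic carbon carries a group of 6 heavy atoms with its own six-membered aromatic ring without a step beyond the scatter. The earlier steps shown here exchanged one whole aryl group for another on the shared core, whereas this step keeps the aryl ring and alters only what it carries. Compound 4 gives 50% and compound 1 gives 50%, the same printed number from two different aryl groups.

Going by these compounds, whether an amine or a carboxylic acid in place of the bromo would stay within the scatter of compound 2 remains open, as does the effect of a longer chain there. Nothing at hand explains how the read-out responds to the group at this place.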